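From Bromo to Methylsulfanyl: A Small Step Expected

This account rests on a few compounds, and the source may have more. Where it says the series, first, only, none or still open, it means among the compounds named here.

In an ADME assay on MT4 cells (Homo sapiens) for cytotoxicity, read by MTT assay, with a stated time of 4 days (a lower number here means that less compound is tolerated, a higher number that more compound is tolerated), compound 2 `O=C(COc1cccc2ccccc12)N/N=C/c1ccc(Br)cc1` gives 106 ug/mL, and compound 1 `O=C(COc1cccc2ccccc12)N/N=C/C=C/c1ccccc1` gives 82.7 ug/mL, so the two numbers lie within the usual scatter of each other. Compound 3 `CSc1ccc(/C=N/NC(=O)COc2cccc3ccccc23)cc1` keeps everything in compound 2 except one group, with methylsulfanyl in place of bromo on an aromatic carbon, para to a large group: methylsulfanyl in place of bromo on an aromatic carbon. Within the data shown here, only one measured step exists, a 1.3-fold higher number from compound 1 to compound 2 (0.11 log units; within the scatter), and it bears on this change only loosely, since it concerns different groups. Among the measured compounds shown here, that step stayed within the scatter, and no measured step yet shows what this particular swap does. No step beyond the scatter is therefore expected in this assay. The expected outcome is a 1.1-fold lower number from compound 2 to compound 3 (0.05 log units; within the scatter). Compound 3 is estimated at 95 ug/mL, with an expected range of 45 ug/mL to 190 ug/mL.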

Compound 3, half-maximal cytotoxic concentration: 68.3 ug/mL
For compound 3 the middle estimate is 1.4-fold (0.14 log units) above the measured one, and the stated range covers the measured number.
By their numbers in this assay, from the lowest: compounds 3, 1 and 2 (each within the scatter of the next).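

Among these compounds, the first measured swap of bromo for methylsulfanyl, on an aromatic carbon para to a large group, gives a 1.6-fold lower number from compound 2 to compound 3 (0.19 log units; within the scatter) in this assay. Replacing 2-phenylethenyl with 4-(methylsulfanyl)phenyl on the carbon with a double bond to nitrogen gives a 1.2-fold lower number from compound 1 to compound 3 (0.08 log units; within the scatter), so all three compounds now lie within the usual scatter of one another, and neither change has a measurable effect on this read-out. No measurement available here explains why the numbers stay so close.

Going by these compounds, whether an amine or a carboxylic acid at this same position would carry the number beyond the scatter remains open. So does the outcome for a longer chain on the sulfur, such as ethylsulfanyl or butylsulfanyl, with the rest of the compound unchanged.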